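The source may hold more compounds than are shown below. What is called first, only, known or untested is meant among the compounds shown, and "the series" means these compounds.

compound 1 `CCC[C@@H]1O[C@H](COCc2ccccc2)[C@@H](OCc2ccccc2)[C@H](OCc2ccccc2)[C@H]1O` gives 18900 nM
compound 2 `C=CC[C@@H]1O[C@H](COCc2ccccc2)[C@@H](OCc2ccccc2)[C@H](OCc2ccccc2)[C@H]1O` gives 26200 nM
compound 3 `C=CC[C@@H]1O[C@H](COCc2ccccc2)[C@@H](OCc2ccccc2)[C@H](OCc2ccccc2)[C@H]1OC(C)=O` gives > 50000 nM (a limit)

Going by the values given here, in a functional assay on HeLa cells (Homo sapiens) for antiproliferative activity, read by sulforhodamine B assay (on this read-out lower numbers stand for stronger inhibition of growth and higher numbers for weaker inhibition of growth), compound 2 sits within the scatter of compound 1, and these two are the only actual numbers. Compound 3 reports only a limit (> 50000 nM). Compound 4 `O[C@@H]1[C@@H](OCc2ccccc2)[C@H](OCc2ccccc2)[C@@H](COCc2ccccc2)O[C@H]1Cc1ccccc1` carries phenyl in place of vinyl on a saturated chain carbon bound to a saturated ring carbon, which also reads allyl to benzyl. Among the compounds with values here, the one measured change at this place (a 1.4-fold higher number from compound 1 to compound 2 (0.14 log units; within the scatter)) stayed within the scatter. The other measured step (an at least 1.9-fold higher number from compound 2 to compound 3 (0.28 log units; that floor lies within the scatter)) concerns acetyl on an oxygen, which compound 4 does not carry, so it bears little here. The expected step is none beyond the scatter (a 1.3-fold lower number from compound 2 to compound 4 (0.12 log units; within the scatter)), but a single comparison is thin support, so the range stays wide. For compound 4 the estimated value is 20000 nM (expected range 8000 nM to 45000 nM).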

Compound 4, concentration for 50% growth inhibition: 17400 nM
For compound 4 the middle estimate is 1.1-fold (0.06 log units) above the measured one; the measured number falls inside the stated range.
By their numbers in this assay, from the lowest: compounds 4, 1 and 2 (each within the scatter of the next). At a limit, above all of these: compound 3.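

In this assay, the new compound shows that this place on a saturated chain carbon bound to a saturated ring carbon also accepts a six-membered aromatic ring without leaving the scatter (a 1.5-fold lower number from compound 2 to compound 4 (0.18 log units; within the scatter)). The same holds for phenyl in place of ethyl (a 1.1-fold lower number from compound 1 to compound 4 (0.04 log units; within the scatter)), so the three side chains with actual numbers cannot be told apart. Nothing measured here accounts for this. An amine or a carboxylic acid at this place remains untested among the compounds shown. On these data alone, whether any group here can move the number beyond the scatter also stays open.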